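Cytotoxicity notes: compounds 1 to 4

The source may report more compounds than this note shows. Statements on the series, on what has been measured and on what is new or still open speak of the compounds shown alone.

Measured so far, in a toxicity assay on MDCK cells (Canis lupus familiaris) for cytotoxicity, read by crystal violet staining, with a stated time of 48 h; on this read-out higher numbers stand for lower toxicity in this test and lower numbers for higher toxicity in this test:
- compound 1, `Cc1ccc2cc(CN(Cc3ccc(Cl)cc3)Cc3ccc(Cl)cc3)c(=O)[nH]c2c1`: compound 1 gives > 33000 nM, which is a limit of the assay and not a number.
- compound 2, `CCc1ccc2[nH]c(=O)c(CN(Cc3ccc(C(C)(C)C)cc3)Cc3ccc(F)c(F)c3)cc2c1`: compound 2 gives > 33000 nM, likewise a limit only.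
- compound 3, `CCCOc1ccc(CN(Cc2ccc(C(C)(C)C)cc2)Cc2cc3cc(C)ccc3[nH]c2=O)cc1`: compound 3 gives > 5000 nM, again a limit and not a number.

Compound 3 therefore stands at a limit only, and no number separates it from the others; of the three values shown, two sit at the limit of > 33000 nM in this assay, at which 2 of the 3 values shown sit, and one at the limit of > 5000 nM in this assay, at which 1 of the 3 values shown sits. Among the compounds with values here, no step between two measured compounds is available, so no measured size of change can be drawn on.

Compound 4, `Cc1ccc2[nH]c(=O)c(CN(Cc3ccc(C(C)(C)C)cc3)[C@H](C)c3ccc(F)cc3)cc2c1`, differs from compound 3 in one place: 1-(4-fluorophenyl)ethyl in place of 4-propoxybenzyl on an amine nitrogen. With three limits and no numeric value in this series, no direction can be read for this change; any step in this assay is expected to stay within the scatter, and a further limit is the most likely outcome.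

For compound 4 the expected value in this assay is 40000 nM, estimated to lie between 10000 nM and 120000 nM. The step this estimate means, a step that the limit leaves unreadable from compound 3 to compound 4, is expected not to exceed the scatter.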

Compound 4, half-maximal cytotoxic concentration: > 5000 nM
Compound 4 gave a limit, no number (the forecaster's own chance of this, stated with the estimate: 80%); the middle value is on the limit's open side.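

Compound 3 and compound 4 both stand at a limit and not at a number in this assay, so the step between them cannot be read. The compounds shown leave open whether 1-(4-fluorophenyl)ethyl in place of 4-propoxybenzyl on an amine nitrogen changes the read-out at all.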